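The compounds below may be only part of what the source reports. "The series", "measured", "known", "first", "only" and "open" are said of these compounds alone.

Measured so far in an in vivo ADME assay on the whole organism (strain Sprague-Dawley) for metabolic stability, with Rattus norvegicus as the target, at a dose of 1 mg/kg by the intravenous route; a higher number here means that the compound lasts longer, a lower number that the compound disappears faster:
- Compound 1 `CNc1c(-c2ccc(=O)n(-c3ccccc3C)n2)c(-c2ccc(F)cc2)nn1C` gives 0.66 h
- Compound 2 `Cc1ccccc1-n1nc(-c2c(-c3ccc(F)cc3)nn3c2NC[C@@H](O)C3)ccc1=O` gives 3.89 h

Compound 2 holds the higher of the two values, and the gap down to compound 1 lies beyond the usual scatter. The next compound is compound 3 `Cc1ccccc1-n1nc(-c2c(-c3ccc(F)cc3)nn3c2NC[C@H](O)C3)ccc1=O`, and its difference from compound 2 is the two compounds have the same atoms and bonds and differ only in configuration as drawn: 1 of 1 stereo elements differ; a stereocentre at a saturated ring carbon is drawn R in compound 2 and S in compound 3 (a stereocentre at a saturated ring carbon is drawn R in compound 2 and S in compound 3). Going by the values given here, no measured pair here differs only in configuration, so the data do not show how far such a change moves this assay or in which direction. The expectation therefore stays close to compound 2 at 3.89 h and leans only slightly lower. The expected change, a 1.3-fold lower number from compound 2 to compound 3 (0.11 log units; within the scatter), stays within the scatter. For compound 3 the estimated half-life is 3 h with an expected range from 1.3 h to 6.5 h as the likely span.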

Compound 3, half-life: 9.01 h
Compound 3: the middle estimate sits 3.0-fold (0.48 log units) below what was measured, and the stated range ends below it.
By their numbers in this assay, from the lowest: compound 1; then compound 2; then compound 3.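

In this assay, changing the stereocentre at a saturated ring carbon from R as drawn to S gives a 2.3-fold higher number from compound 2 to compound 3 (0.36 log units; beyond the scatter), a modest step that lies beyond the scatter. Going by these compounds alone, this is the first measured pair that differs only in configuration, and it shows that the half-life at this position responds to the drawn arrangement alone, with the S form lasting longer. The step can be assigned to this stereocentre alone because nothing else separates the pair: the fact that compounds 2 and 3 differ only in the configuration as drawn

The compounds shown leave open how far this preference for S holds on other versions of the shared core, since it rests on one pair. They also leave open how this assay would respond to an amine or a methoxy group at this same saturated ring carbon.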